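Moving a hydroxyl around a piperidinone ring

The compounds below may be only part of what the source reports. "The series", "measured", "known", "first", "only" and "open" are said of these compounds alone.

Measured compounds:
Compound 1 `CC(C)c1noc(N2CCC(Oc3cc(N4CCc5cc(N6CC(O)CCC6=O)ccc54)ncn3)CC2)n1` gives 90 nM in an assay on CHO cells for agonist activity at Glucose-dependent insulinotropic receptor (Homo sapiens), read by a luciferase reporter and cAMP accumulation, with a stated time of 2 h; on this read-out higher numbers stand for an effect only at larger amounts of compound and lower numbers for an effect already at smaller amounts.
Compound 2 `CC(C)SC(=O)N1CCC(Oc2cc(N3CCc4ccccc43)ncn2)CC1` gives > 10000 nM in this assay, and this is a limit of the assay rather than a number.

Compound 1 therefore stands as the only real number shown; the other value is the limit of > 10000 nM in this assay, at which 1 of the 2 values shown sits. Compound 3 `CC(C)c1noc(N2CCC(Oc3cc(N4CCc5cc(N6CCC(O)CC6=O)ccc54)ncn3)CC2)n1` is built from compound 1 by 4-hydroxy-2-oxopiperidin-1-yl in place of 5-hydroxy-2-oxopiperidin-1-yl on an aromatic carbon. The two share every atom, and the only difference is which carbon of the six-membered non-aromatic ring carries the hydroxyl. Going by the values given here, no pair of measured compounds that differ in a single place is available, so nothing measured tells how large such a shift of a hydroxyl might be in this assay. With the atoms unchanged and the group kept on the same aromatic carbon, the expectation is a step of no more than the usual scatter, or at most a slight loss. Compound 3 is estimated to give 120 nM, with a range from 40 nM to 400 nM. The expected step is a 1.3-fold higher number from compound 1 to compound 3 (0.12 log units; within the scatter), essentially a standstill within the scatter.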

Compound 3, half-maximal effective concentration: 89 nM
Compound 3: middle estimate off by 1.3-fold (0.13 log units), on the high side; low and high end bracket the measured number.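

Going by these compounds alone, this pair gives the first measured step that changes one place only, and it sets a scale for a move of this kind: the step in this assay is a 1.0-fold lower number from compound 1 to compound 3 (0.00 log units; within the scatter) and so lies inside the usual spread of repeat measurements. The read-out therefore does not separate 4-hydroxy-2-oxopiperidin-1-yl from 5-hydroxy-2-oxopiperidin-1-yl on this aromatic carbon, so the exact ring carbon that carries the hydroxyl makes no measurable difference between these two groups. Nothing measured here offers a reason for this flat step, and no available observation bears on it.

The compounds shown leave open whether the hydroxyl contributes at all, since every comparison so far keeps it in the molecule, and a plain 2-oxopiperidin-1-yl group or one carrying a methoxy or an amine in place of the hydroxyl would test that directly. They also leave open how much room this aromatic carbon allows for a different group altogether, such as a carboxylic acid or a longer chain ending in a hydroxyl.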